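The compounds below may be only part of what the source reports. "The series", "measured", "known", "first", "only" and "open" are said of these compounds alone.

Measured compounds in a functional assay on A549 cells (Homo sapiens) for antiproliferative activity, read by MTT assay, with a stated time of 48 h; a higher number here means a weaker inhibitor, a lower number a stronger inhibitor:
compound 1 `O=c1cc(-c2ccccc2)oc2cc(OCc3ccccc3)c(OCCCCN3CCCCC3)c(O)c12` gives 1900 nM
compound 3 `O=c1cc(-c2ccccc2)oc2cc(OCc3ccccc3)c(OCCCN3CCCC3)c(O)c12` gives 1400 nM
compound 2 `COc1cc2oc(-c3ccccc3)cc(=O)c2c2c1OCCCCO2` gives only > 100000 nM, a limit of the assay rather than a number.

Compound 1 stands highest of the two numbers in this assay; its nearest neighbour is compound 3, with a 1.4-fold lower number from compound 1 to compound 3 (0.13 log units; within the scatter). Compound 4 `COc1cc2oc(-c3ccccc3)cc(=O)c2c(O)c1OCCCCN1CCCCC1` is not yet measured. It differs from compound 1 by hydrogen in place of phenyl on a saturated chain carbon bound to an oxygen on an aromatic ring. For the measured compounds named here, none of the measured steps touches this position: a 1.4-fold lower number from compound 1 to compound 3 (0.13 log units; within the scatter) concerns the amine end of the chain and lies within the scatter, and the limit of > 100000 nM in this assay, at which 1 of the 3 values shown sits, belongs to a compound altered in more than one place. Compound 4 is therefore expected to sit somewhat higher than compound 1, by a 2.1-fold higher number from compound 1 to compound 4 (0.32 log units; beyond the scatter), though the measured steps give no firm direction. The estimate for compound 4 is 4000 nM, range 1200 nM to 15000 nM.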

Compound 4, half-maximal inhibitory concentration: 34000 nM
For compound 4 the middle estimate is 8.5-fold (0.93 log units) below the measured one, and the stated range ends below it.
By their numbers in this assay, from the lowest: compounds 3 and 1 (each within the scatter of the next); then compound 4. At a limit, above all of these: compound 2.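

In this assay, for the compounds shown here, benzyloxy to methoxy on the shared core gives an 18-fold higher number from compound 1 to compound 4 (1.25 log units; beyond the scatter), so this position responds strongly to the change, unlike the amine end of the chain, where the only measured step is a 1.4-fold lower number from compound 1 to compound 3 (0.13 log units; within the scatter). The phenyl group is therefore a large contributor to the value of compound 1 in this assay. Nothing among the data shown gives a reason for this step.

As far as these compounds go, it remains open whether a fluorobenzyl, a pyridylmethyl or a longer alkyl chain at this position would restore the value. From the compounds shown here alone, it is also open whether the step would be the same with the pyrrolidin-1-yl chain of compound 3.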